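Thiophen-2-yl in place of furan-2-yl: expectation for compound 4

This account rests on a few compounds, and the source may have more. Where it says the series, first, only, none or still open, it means among the compounds named here.

Measured in an assay on liver (Sus scrofa) for inhibition of glucose-6-phosphatase catalytic subunit 1 (Homo sapiens), using microsomes; a lower number here means a stronger inhibitor, a higher number a weaker inhibitor:
compound 1 `C(=N/N(Cc1ccccc1)Cc1ccccc1)\c1ccccc1`: 1500 nM
compound 2 `COc1ccccc1/C=N/N(Cc1ccccc1)Cc1ccccc1`: > 100000 nM, a limit of the assay, not a number
compound 3 `C(=N/N(Cc1ccccc1)Cc1ccccc1)\c1ccco1`: 1100 nM

Compound 3 gives the lowest of the two numbers in this assay; its nearest neighbour is compound 1, and the difference a 1.4-fold lower number from compound 1 to compound 3 (0.13 log units; within the scatter) lies within the scatter, so no order between the two can be claimed. Compound 2 is known only as a limit (the limit of > 100000 nM in this assay, at which 1 of the 3 values shown sits). The step of an at least 90-fold lower number from compound 2 to compound 3 (1.95 log units; beyond the scatter) is large, as is an at least 66-fold higher number from compound 1 to compound 2 (1.82 log units; beyond the scatter), but both involve the methoxy-bearing ring and not a bare exchange of the aryl group.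

Compound 4 `C(=N/N(Cc1ccccc1)Cc1ccccc1)\c1cccs1` differs from compound 3 in one place: thiophen-2-yl in place of furan-2-yl on a carbon with a double bond to nitrogen. The step that bears on this is the exchange of the aryl group on that same carbon, from compound 1 to compound 3, which was a 1.4-fold lower number from compound 1 to compound 3 (0.13 log units; within the scatter), within the scatter. The expected step of no change at the digits printed from compound 3 to compound 4 (within the scatter) is therefore none beyond the scatter. Compound 4 is estimated at 1100 nM, with a range from 400 nM to 3000 nM.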

Compound 4, half-maximal inhibitory concentration: 1500 nM
The estimate for compound 4 lay 1.4-fold (0.13 log units) below the measured number, within the range that was stated.
By their numbers in this assay, from the lowest: compounds 3, 1 and 4 (each within the scatter of the next). At a limit, above all of these: compound 2.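

In this assay thiophen-2-yl joins furan-2-yl and phenyl as a third bare aromatic ring on the carbon with a double bond to nitrogen, and no separation appears among the three: a 1.4-fold higher number from compound 3 to compound 4 (0.13 log units; within the scatter) and no change at the digits printed from compound 1 to compound 4 (within the scatter). Sulfur in place of oxygen in the five-membered ring therefore moves the number by no more than the scatter, and the only large change at this position remains the one involving 2-methoxyphenyl, an at least 66-fold lower number from compound 2 to compound 4 (1.82 log units; beyond the scatter). That step rests on a limit of the assay for compound 2, not a number: the limit of > 100000 nM in this assay, at which 1 of the 4 values shown sits.

From the compounds shown here alone, what remains open is whether the methoxy group itself sets compound 2 apart, or whether a chlorine, an amine or a carboxylic acid on the ring would do the same. Going by these compounds, the two benzyl groups are also constant throughout, so the effect of a longer chain in their place is unknown.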